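Phenyl to 5-methylfuran-2-yl on the shared core

The source may hold more compounds than are shown below. What is called first, only, known or untested is meant among the compounds shown, and "the series" means these compounds.

Going by the values given here, in a functional assay on NCI-H460 cells (Homo sapiens) for cytotoxicity, read by MTT assay, with a stated time of 72 h (a higher number here means a weaker inhibitor, a lower number a stronger inhibitor), compound 2 (`O=c1[nH]/c(=C\c2cccc(Oc3ccc(F)cc3)c2)c(=O)[nH]/c1=C\c1ccccc1`) gives 389 nM, the highest of the two numbers so far, while compound 1 (`CC(C)(C)c1[nH]cnc1/C=c1\[nH]c(=O)/c(=C/c2cccc(Oc3ccc(F)cc3)c2)[nH]c1=O`) gives 4 nM. Compound 3 (`Cc1ccc(/C=c2\[nH]c(=O)/c(=C/c3cccc(Oc4ccc(F)cc4)c3)[nH]c2=O)o1`) remains unmeasured. It differs from compound 2 in one place: 5-methylfuran-2-yl in place of phenyl on a double-bonded chain carbon bound to an aromatic carbon. Here 5-methylfuran-2-yl stands in place of phenyl on a double-bonded chain carbon bound to an aromatic carbon. Among the compounds with values here, only one measured step bears on this place: a 97-fold higher number from compound 1 to compound 2 (1.99 log units; beyond the scatter), a large step beyond the scatter, in which phenyl replaces 5-(tert-butyl)-1H-imidazol-4-yl. Within the data shown here, no measurement yet covers the 5-methylfuran-2-yl group itself, so compound 3 is expected to regain only part of that step, a moderate move towards a lower number in this assay. The estimated change is a 3.2-fold lower number from compound 2 to compound 3 (0.51 log units; beyond the scatter). For compound 3 the expected value is 120 nM, with an estimated range of 25 nM to 500 nM.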

Compound 3, half-maximal inhibitory concentration: 30 nM
Compound 3: the middle estimate sits 4.0-fold (0.60 log units) above what was measured; the range from low to high includes it.
By their numbers in this assay, from the lowest: compound 1; then compound 3; then compound 2.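

In this assay, the step of a 13-fold lower number from compound 2 to compound 3 (1.11 log units; beyond the scatter) is large, showing that much of what is lost with phenyl on the double-bonded chain carbon bound to an aromatic carbon can be recovered without the 5-(tert-butyl)-1H-imidazol-4-yl group. That group still keeps an edge at this place: the step of a 7.5-fold higher number from compound 1 to compound 3 (0.88 log units; beyond the scatter) is modest but beyond the scatter, so 5-methylfuran-2-yl closes only part of the gap. Nothing given here accounts for either step.

The compounds shown leave open whether the gain of compound 3 over compound 2 rests on the furan ring oxygen or on the methyl group, and whether the tert-butyl group or the imidazole ring matters more in compound 1. An unsubstituted furan-2-yl, or an ethyl or aminomethyl group in place of that methyl, would begin to separate these.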